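The compounds below may be only part of what the source reports. "The series", "measured", "known", "first", "only" and "open" are said of these compounds alone.

Three compounds share one core and differ only in the group that sits on the aromatic carbon next to the ring sulfur of the five-membered ring. Compound 1 `CC(C)(C)Cc1c(-c2ccoc2)sc(N)c1C(=O)c1ccc(Cl)cc1` carries furan-3-yl there, compound 2 `CC(C)(C)Cc1c(-c2ccncc2)sc(N)c1C(=O)c1ccc(Cl)cc1` pyridin-4-yl, and compound 3 `Cc1ccc(-c2sc(N)c(C(=O)c3ccc(Cl)cc3)c2CC(C)(C)C)cc1` 4-methylphenyl. In an assay on CHO cells for displacement of a labelled ligand from adenosine receptor A1 (Homo sapiens), read by scintillation counting, tested at 10 uM (a higher number here means more inhibition at the concentration tested (going by the name of the read-out), a lower number less inhibition), compound 1 gives 1%, compound 2 gives 1%, and compound 3 gives 1%. The steps between them, no change at the digits printed from compound 1 to compound 2 (within the scatter), no change at the digits printed from compound 1 to compound 3 (within the scatter) and no change at the digits printed from compound 2 to compound 3 (within the scatter), all lie within the scatter, so compound 3 stands level with compounds 1 and 2 at this position, and none of the three can be called stronger or weaker than the others.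

Compound 4 `CC(C)(C)Cc1c(Br)sc(N)c1C(=O)c1ccc(Cl)cc1` is not yet measured. The change from compound 3 is bromo in place of 4-methylphenyl on an aromatic carbon. The three measured steps all swap one ring for another at this same place without moving the read-out, but none brings in bromo or removes the ring entirely. Lacking a direct precedent, and with every measured swap at this place flat, a step of a number 1 percentage points higher from compound 3 to compound 4 (within the scatter) is expected, with no change beyond the scatter. In this assay compound 4 is therefore estimated at 2%, within a range from -6% to 12%.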

Compound 4, a percentage reported as inhibition, at one concentration (the size of the read-out at that concentration, not a potency): 1%
The estimate for compound 4 lay 1 percentage points above the measured number; low and high end bracket the measured number.
By their numbers in this assay, from the lowest: compounds 1, 2, 3 and 4 (each within the scatter of the next).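

The new change is of a different kind: where every earlier swap put one ring in place of another, bromo has no ring at all, yet the read-out in this assay shows no change at the digits printed from compound 3 to compound 4 (within the scatter), along with no change at the digits printed from compound 2 to compound 4 (within the scatter) and no change at the digits printed from compound 1 to compound 4 (within the scatter). Among these four compounds, then, a ring at this place makes no readable difference, and neither does the size of the group, from bromo up to 4-methylphenyl. No measurement at hand offers an explanation for this flat result.

Going by these compounds, whether an amine, a carboxylic acid or a longer chain at this place would move the number remains open. On these data alone, since only this one place varies, it is also open what changes to the neopentyl, amino or (4-chlorophenyl)carbonyl groups would do.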